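This account rests on a few compounds, and the source may have more. Where it says the series, first, only, none or still open, it means among the compounds named here.

Measured compounds:
compound 1 `Cn1cnc(CN2CCN(c3cccc4[nH]c(-c5ccc(C(C)(C)C)cc5)nc34)CC2)c1` — 33 nM
compound 2 `CCCn1cc(CN2CCN(c3cccc4[nH]c(-c5ccc(C(C)(C)C)cc5)nc34)CC2)nc1C` — 18 nM

Both compounds share a core carrying a tert-butylphenyl group and a piperazine, and they differ only in the imidazole attached through a methylene to the piperazine nitrogen. In an assay on isolated protein for displacement of a labelled ligand from Gonadotropin-releasing hormone receptor (Homo sapiens) (a lower number here means a stronger inhibitor, a higher number a weaker inhibitor), compound 1 gives 33 nM, and compound 2 gives 18 nM. On these two numbers compound 2 stands at the lower end, but the only step shown, a 1.8-fold lower number from compound 1 to compound 2 (0.26 log units; within the scatter), does not separate the two compounds.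

Compound 3 `CCCn1c(CC)nc(C)c1CN1CCN(c2cccc3[nH]c(-c4ccc(C(C)(C)C)cc4)nc23)CC1` continues from compound 2 with one change: 2-ethyl-4-methyl-1-propyl-1H-imidazol-5-yl in place of 2-methyl-1-propyl-1H-imidazol-4-yl on a saturated chain carbon bound to an amine nitrogen in a ring. Among the compounds with values here, the single measured step that bears on it, a 1.8-fold lower number from compound 1 to compound 2 (0.26 log units; within the scatter), also altered the substitution of this imidazole and stayed within the scatter. Within the data shown here, there is no measured step that moves the point of attachment of the imidazole or adds an ethyl group, so the data give no ground for a shift in either direction. Compound 3 is therefore expected to stay close to compound 2 in this assay, with an estimated step of no change at the digits printed from compound 2 to compound 3 (within the scatter). The estimate for compound 3 is 18 nM, within a range of 5 nM to 60 nM.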

Compound 3, half-maximal inhibitory concentration: 57 nM
The estimate for compound 3 lay 3.2-fold (0.50 log units) below the measured number, within the range that was stated.
By their numbers in this assay, from the lowest: compounds 2, 1 and 3 (each within the scatter of the next, the first and the last beyond it).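

In this assay, within the data shown here, the change at this position registers as a 3.2-fold higher number from compound 2 to compound 3 (0.50 log units; beyond the scatter), the first step to pass beyond the scatter, so this imidazole on a saturated chain carbon bound to an amine nitrogen in a ring does not tolerate every change without a measurable shift. The effect is limited, however, as the other listed comparison is a 1.7-fold higher number from compound 1 to compound 3 (0.24 log units; within the scatter), which leaves compound 3 unseparated from compound 1 even though the two imidazoles differ in substitution and point of attachment. Nothing available accounts for the shift between compound 2 and compound 3.

The exchange of 2-methyl-1-propyl-1H-imidazol-4-yl for 2-ethyl-4-methyl-1-propyl-1H-imidazol-5-yl alters the ethyl, the methyl and the point of attachment together, so the compounds shown leave open which of these carries the step. They also leave open how this assay would read with a butyl chain in place of the propyl, or with a carboxylic acid or a primary amine on the imidazole.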